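This account rests on a few compounds, and the source may have more. Where it says the series, first, only, none or still open, it means among the compounds named here.

Measured in an ADME assay on liver (Homo sapiens) for metabolic stability, using microsomes; on this read-out lower numbers stand for a shorter-lived compound and higher numbers for a longer-lived compound:
- compound 1 `CN1Cc2cc(ccc2S(=O)(=O)C2CC2)NC(=O)CCc2cccc(c2)[C@@H](Nc2ccc3c(N)ncc(F)c3c2)C1=O`: 0.217 h
- compound 2 `COc1ccc2cc1CCC(=O)Nc1ccc(S(=O)(=O)C3CC3)c(c1)CN(C)C(=O)[C@@H]2Nc1ccc2c(N)ncc(F)c2c1`: 0.233 h
- compound 3 `COc1c(F)cc2cc1CCC(=O)Nc1ccc(S(=O)(=O)C3CC3)c(c1)CN(C)C(=O)[C@@H]2Nc1ccc2c(N)ncc(F)c2c1`: 0.233 h

Compound 2 gives 0.233 h, level with compound 3 and within the scatter of compound 1. Compound 4 `CN1Cc2cc(ccc2S(=O)(=O)C2CC2)NC(=O)CCc2cc(ccc2OCC(F)F)[C@@H](Nc2ccc3c(N)ncc(F)c3c2)C1=O` is the next to be read. Its difference from compound 2 is difluoromethyl in place of hydrogen on a saturated chain carbon bound to an oxygen on an aromatic ring, which turns methoxy into 2,2-difluoroethoxy. For the measured compounds named here, two measured steps bear on this: a 1.1-fold higher number from compound 1 to compound 2 (0.03 log units; within the scatter) with methoxy in place of hydrogen, and no change at the digits printed from compound 2 to compound 3 (within the scatter) with fluoro in place of hydrogen. Both lie within the scatter, but neither alters the chain on that oxygen, so the support is indirect. The expected change is a 1.0-fold higher number from compound 2 to compound 4 (0.01 log units; within the scatter), with no step beyond the scatter and no favoured direction. In this assay the estimate for compound 4 is 0.24 h, with an expected range of 0.13 h to 0.45 h.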

Compound 4, half-life: 0.533 h
Estimate against measurement, compound 4: 2.2-fold (0.35 log units) below; measured number above the stated range.
By their numbers in this assay, from the lowest: compounds 1, 2 and 3 (each within the scatter of the next); then compound 4.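

In this assay, the chain on the oxygen is the only place among these compounds where a change goes beyond the scatter, with a 2.3-fold higher number from compound 2 to compound 4 (0.36 log units; beyond the scatter) for methyl to 2,2-difluoroethyl. Against the compound without an oxygen substituent, the 2,2-difluoroethoxy group gives a 2.5-fold higher number from compound 1 to compound 4 (0.39 log units; beyond the scatter), whereas methoxy stayed within the scatter, so the step appears only once the chain on that oxygen changes. Nothing shown accounts for the step. Going by these compounds, whether an unfluorinated ethoxy, a 2,2,2-trifluoroethoxy or a longer chain such as propoxy would give a similar step remains open.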